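The source may report more compounds than this note shows. Statements on the series, on what has been measured and on what is new or still open speak of the compounds shown alone.

Measured compounds in a functional assay on A549 cells (Homo sapiens) for cytotoxicity, read by MTT assay, with a stated time of 72 h; a lower number here means a stronger inhibitor, a higher number a weaker inhibitor:
- compound 1 `O=C(Nc1ccc(Oc2ccnc3[nH]ccc23)cc1)c1nn(-c2ccc(Cl)cc2)ccc1=O`: 25100 nM
- compound 2 `O=C(Nc1ccc(Oc2ccnc3[nH]ccc23)c(F)c1)c1nn(-c2ccccc2)ccc1=O`: 56800 nM
- compound 3 `Cn1ccc2c(Oc3ccc(NC(=O)c4nn(-c5ccc(Cl)cc5)ccc4=O)cc3)ccnc21`: this value is a limit of the assay, > 60000 nM, not a number.

Compound 3 therefore stands at the weak end of what has been measured in this assay; no number is known for it, only that it exceeds the limit (the limit of > 60000 nM in this assay, at which 1 of the 3 values shown sits). Among the measured compounds shown here, the one step that leads to it, an at least 2.3-fold higher number from compound 1 to compound 3 (0.37 log units; beyond the scatter), is the methyl in place of hydrogen on an aromatic nitrogen, and it is beyond the scatter.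

Compound 4 `Cn1ccc2c(Oc3ccc(NC(=O)c4nn(-c5ccc(Br)cc5F)ccc4=O)cc3)ccnc21` differs from compound 3 in the aryl group on the pyridazinone nitrogen: 4-bromo-2-fluorophenyl in place of 4-chlorophenyl on an aromatic nitrogen. For the measured compounds named here, no measured step isolates a change of this aryl group. Going by the values given here, compound 1 and compound 2 differ in two places at once, so their values show only that both are weak; no step between them can be read.

With nothing to anchor a shift, the expected step that the limit leaves unreadable from compound 3 to compound 4 is none beyond the scatter, and compound 4 is estimated at 70000 nM, range 30000 nM to 160000 nM, most likely again reported only as a limit.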

Compound 4, half-maximal inhibitory concentration: 35700 nM
For compound 4 the middle estimate is 2.0-fold (0.29 log units) above the measured one, within the range that was stated.
By their numbers in this assay, from the lowest: compounds 1, 4 and 2 (each within the scatter of the next, the first and the last beyond it). At a limit, above all of these: compound 3.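

The value of compound 3 in this assay is a limit, not a number: the limit of > 60000 nM in this assay, at which 1 of the 4 values shown sits. As far as these compounds go, the change to 4-bromo-2-fluorophenyl in place of 4-chlorophenyl on an aromatic nitrogen gives an at least 1.6-fold lower number from compound 3 to compound 4 (0.22 log units; that floor lies within the scatter), so the true size of this step remains unknown and a real change cannot be claimed. Among the compounds shown here, what compound 4 adds is a first readable number for a compound with the methyl on the aromatic nitrogen of the shared core, showing that this aryl position accepts two halogens with a measurable value in this assay.

The compounds shown do not separate the bromine from the fluorine, and they leave open how compound 4 would read with hydrogen in place of that methyl. Also open, from the compounds shown here alone, is how this aryl group would read in this assay if it carried an amine or a carboxylic acid.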